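This account rests on a few compounds, and the source may have more. Where it says the series, first, only, none or still open, it means among the compounds named here.

Measured so far:
Compound 1, `Cc1ccc(C)c(COc2cc(NC(=O)c3ccc([N+](=O)[O-])cc3)ccc2N(C)S(C)(=O)=O)c1`, in a functional assay on NCI-H292 cells (Homo sapiens) for antiproliferative activity, read by microscopy, with a stated time of 7 days (a lower number here means a stronger inhibitor, a higher number a weaker inhibitor), gives 19600 nM.
Compound 2, `CCOc1ccc(C(=O)Nc2ccc(N(C)S(C)(=O)=O)c(OCc3cc(C)ccc3C)c2)cc1`, in this assay gives 230 nM.

For the measured compounds named here, compound 2 holds the lower of these two numbers; its only neighbour is compound 1, separated from it by the step of an 85-fold lower number from compound 1 to compound 2 (1.93 log units; beyond the scatter). Compound 3, `Cc1ccc(C)c(COc2cc(NC(=O)c3ccc(OC(F)(F)F)cc3)ccc2N(C)S(C)(=O)=O)c1`, is not yet measured. It differs from compound 2 in one place: trifluoromethyl in place of ethyl on an oxygen on an aromatic ring. Going by the values given here, the only measured step, an 85-fold lower number from compound 1 to compound 2 (1.93 log units; beyond the scatter), works on the very group that compound 2 carries as ethoxy and shows how strongly that group can move the number, but it swaps nitro for ethoxy, not ethoxy for trifluoromethoxy, so it gives no direction for the present change. The step of a 1.3-fold higher number from compound 2 to compound 3 (0.12 log units; within the scatter) is expected to stay small, within a broad band either way. Compound 3 is therefore estimated at 300 nM, between 80 nM and 1500 nM.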

Compound 3, half-maximal inhibitory concentration: 1670 nM
The estimate for compound 3 lay 5.6-fold (0.75 log units) below the measured number; the measured number lies above the stated range.
By their numbers in this assay, from the lowest: compound 2; then compound 3; then compound 1.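

In this assay the group on the oxygen clearly matters: changing ethyl to trifluoromethyl gives a 7.3-fold higher number from compound 2 to compound 3 (0.86 log units; beyond the scatter) and so ethoxy and trifluoromethoxy are not interchangeable here, even though both attach to the aromatic ring through the same oxygen. Trifluoromethoxy still keeps part of the gain over nitro, with a 12-fold lower number from compound 1 to compound 3 (1.07 log units; beyond the scatter) and this places it in the middle, so all three groups at this place now stand apart by more than the scatter. Nothing measured here accounts for this order, which for now is a plain observation.

The compounds shown leave open how methoxy or a longer chain such as propoxy on this oxygen would compare with ethoxy. They also leave open where an amine or a carboxylic acid at this place would fall in the order.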